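Chloro for methyl: a step in oral bioavailability

The compounds below may be only part of what the source reports. "The series", "measured", "known", "first", "only" and "open" are said of these compounds alone.

Measured compounds:
compound 1, `Cc1ccc(C(=O)NC2CC2)cc1-c1cc2cnnc(-c3ccc(F)cc3F)c2n(C)c1=O`, in an in vivo ADME assay on the whole organism (strain Sprague-Dawley) for pharmacokinetics, with Rattus norvegicus as the target, at a dose of 2 mg/kg by the oral route (a higher number here means that a larger share of the oral dose reaches the circulation, a lower number that a smaller share of the oral dose reaches the circulation), compound 1 gives 86%
compound 2, `Cc1cnc(C(=O)NC2CC2)cc1-c1cc2cnnc(-c3ccccc3C)c2n(C)c1=O`, in this assay compound 2 gives 132%

Compound 2 stands highest of the two numbers; compound 1 lies lower, beyond the scatter. Compound 3, `Cc1cnc(C(=O)NC2CC2)cc1-c1cc2cnnc(-c3ccccc3Cl)c2n(C)c1=O`, differs from compound 2 by chloro in place of methyl on an aromatic carbon. Going by the values given here, no step between measured compounds covers this change, so the expected step from compound 2 to compound 3 in this assay is estimated at a number 12 percentage points lower from compound 2 to compound 3 (beyond the scatter), not beyond the scatter. Compound 3 is therefore expected to give 120%, between 80% and 160%.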

Compound 3, oral bioavailability: 57%
Compound 3: middle estimate off by 63 percentage points, on the high side; the whole stated range lies above it.
By their numbers in this assay, from the lowest: compound 3; then compound 1; then compound 2.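

On an aromatic carbon ortho to a large group, the change from 2-methylphenyl to 2-chlorophenyl gives in this assay a number 75 percentage points lower from compound 2 to compound 3 (beyond the scatter). This shows that one exchanged atom at this position can by itself move oral bioavailability, which compounds 1 and 2, differing in several places, could not show. Nothing available here accounts for the step. As far as these compounds go, whether a methoxy group, an ethyl chain or an amine at this place would stand nearer compound 2 or compound 3 remains open. Also open, from the compounds shown here alone, is whether the exchange carries over to other members.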